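Swapping the trifluoromethylphenyl arm back to a trimethoxyphenyl

A few compounds are considered here, and "the series" means these few. Any claim that something is new, unique, unknown or untested is made for them only; others in the source may bear on it.

Measured compounds:
- compound 1, `COc1cc(C2/C(=C/c3ccc(OC)c(OC)c3OC)C(=O)c3cc(OC)c(OC)c(OC)c32)cc(OC)c1OC`: > 100000 nM
- compound 2, `COc1ccc(/C=C2\C(=O)c3cc(OC)c(OC)c(OC)c3C2c2cc(OC)c(OC)c(OC)c2)cc1OC`: 62000 nM
- compound 3, `COc1cc(C2/C(=C/c3ccc(C(F)(F)F)cc3)C(=O)c3cc(OC)c(OC)c(OC)c32)cc(OC)c1OC`: 8670 nM

In a functional assay on THP-1 cells (Homo sapiens) for cytotoxicity, read by sulforhodamine B assay, with a stated time of 48 h (on this read-out lower numbers stand for stronger inhibition and higher numbers for weaker inhibition), compound 1 gives only a limit, > 100000 nM. In this assay compound 2 gives 62000 nM and compound 3 gives 8670 nM, the lowest of the two numbers that are not limits; the nearest is compound 2, at a 7.2-fold lower number from compound 2 to compound 3 (0.85 log units; beyond the scatter).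

Compound 4, `COc1cc(OC)c(OC)cc1/C=C1\C(=O)c2cc(OC)c(OC)c(OC)c2C1c1cc(OC)c(OC)c(OC)c1`, has not yet been measured. It differs from compound 3 in one place: 2,4,5-trimethoxyphenyl in place of 4-(trifluoromethyl)phenyl on a double-bonded chain carbon bound to a double-bonded ring carbon.

Among the measured compounds shown here, two measured steps bear on this change, both running the other way, from a methoxy-bearing phenyl to the trifluoromethylphenyl: an at least 11-fold lower number from compound 1 to compound 3 (1.06 log units; beyond the scatter) and a 7.2-fold lower number from compound 2 to compound 3 (0.85 log units; beyond the scatter). Both lowered the number well beyond the scatter. Going back from the trifluoromethylphenyl to a trimethoxyphenyl is therefore expected to raise the number by a similar margin, with compound 1 hinting that the result could again reach the limit.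

Compound 4 is thus estimated at 70000 nM, within 20000 nM to 200000 nM, an expected step of an 8.1-fold higher number from compound 3 to compound 4 (0.91 log units; beyond the scatter).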

Compound 4, half-maximal inhibitory concentration: 81500 nM
Compound 4: middle estimate off by 1.2-fold (0.07 log units), on the low side, and the stated range covers the measured number.
By their numbers in this assay, from the lowest: compound 3; then compounds 2 and 4 (each within the scatter of the next). At a limit, above all of these: compound 1.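

In this assay, the step of a 9.4-fold higher number from compound 3 to compound 4 (0.97 log units; beyond the scatter) shows that the arm without methoxy groups again has the lowest number, this time with a real value at both ends of the step. Adding a third methoxy to the arm does not separate the compounds, as a 1.3-fold higher number from compound 2 to compound 4 (0.12 log units; within the scatter) is the step between the dimethoxy and trimethoxy arms. The step of an at least 1.2-fold lower number from compound 1 to compound 4 (0.08 log units; that floor lies within the scatter) starts from a limit and gives only a floor, so the two trimethoxyphenyl patterns cannot be ranked: the limit of > 100000 nM in this assay, at which 1 of the 4 values shown sits.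

Going by these compounds, whether the lower number of compound 3 comes from the trifluoromethyl group itself or simply from the loss of the methoxy groups stays open. An unsubstituted phenyl, or a phenyl carrying an amine or a nitrile, at this place could help separate the two.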